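This account rests on a few compounds, and the source may have more. Where it says the series, first, only, none or still open, it means among the compounds named here.

Measured so far in an assay on HEK293 cells for positive allosteric modulation of metabotropic glutamate receptor 2 (Rattus norvegicus), read by thallium flux, with a stated time of 2.5 min; a higher number here means a larger maximal response, a lower number a smaller maximal response:
compound 1, `COc1cc(C(=O)O)ccc1OCCCCOc1ccc(C(=O)C(C)C)c(O)c1C`, 73.1%
compound 2, `COc1cc(C(=O)O)ccc1OCCCCOc1ccc(C(=O)CC(C)C)c(O)c1C`, 85.7%
compound 3, `CCCC(=O)c1ccc(OCCCCOc2ccc(C(=O)O)cc2C)c(C)c1O`, 79.3%

Compound 2 gives the top number of the three. Going by the values given here, compound 3 sits within the scatter of it, while compound 1 sits beyond; the one measured step, a number 12.6 percentage points higher from compound 1 to compound 2 (beyond the scatter), is the only change in one place that the set allows to be counted, and it concerns isobutyl in place of isopropyl on a carbonyl carbon, not the ring bearing the carboxy group.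

Compound 4, `Cc1c(OCCCCOc2ccc(C(=O)O)cc2)ccc(C(=O)CC(C)C)c1O`, differs from compound 2 in one place: hydrogen in place of methoxy on an aromatic carbon. Among the compounds with values here, no measured step touches this position. Compound 3 differs from compound 2 in more than one place, so the two values of compound 2 and compound 3 can only be set side by side; they lie within the scatter of each other, which gives no sign that a change on the ring carrying the carboxy group moves the maximal response much. The expectation for compound 4 in this assay is therefore a step of about a number 4.7 percentage points lower from compound 2 to compound 4 (within the scatter) from compound 2, that is no change beyond the scatter. Compound 4 is estimated at 81%, with a range from 66% to 96%.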

Compound 4, largest response reached (reported as percent of maximum), in percent of the reference or control that the assay uses: 88%
Beside the measured number, compound 4's estimate is 7 percentage points below it; low and high end bracket the measured number.
By their numbers in this assay, from the lowest: compounds 1, 3, 2 and 4 (each within the scatter of the next, the first and the last beyond it).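

In this assay, going by these compounds alone, hydrogen in place of methoxy on an aromatic carbon, ortho to a large group and meta to a carboxy group, gives a number 2.3 percentage points higher from compound 2 to compound 4 (within the scatter), the first step that can be read at this position. Within the data shown here, for this one pair, the methoxy, with its 2 heavy atoms and 1 hydrogen-bond acceptor, is not needed to hold the maximal response: compound 4, at 88%, stays within the scatter of compound 2, and the earlier compounds offered only a side-by-side reading on this ring. No supporting data are at hand that would account for this result.

Still open is whether the same swap reads the same way with isopropyl on the carbonyl carbon, since the pair shown carries isobutyl there. Also open, as far as these compounds go, is how other groups on this aromatic carbon, such as fluorine, ethoxy or an amine, would behave in this assay, and whether any of them would move the maximal response beyond the scatter.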